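The compounds below may be only part of what the source reports. "The series", "measured", "known", "first", "only" and "open" are said of these compounds alone.

Compound 3 `CC(=O)NCCN(c1ccccc1)[C@H]1c2cc(C#N)ccc2OC(C)(C)[C@@H]1O` carries acetamidomethyl on a saturated chain carbon bound to a nitrogen on an aromatic ring. In a functional assay (aorta) with Rattus norvegicus as the target (on this read-out lower numbers stand for stronger inhibition and higher numbers for weaker inhibition), compound 3 gives > 30000 nM, which is a limit of the assay rather than a number. Compound 1 `CCOC(=O)CN(c1ccccc1)[C@H]1c2cc(C#N)ccc2OC(C)(C)[C@@H]1O` gives > 30000 nM, likewise a limit. Compound 2 `CCOC(=O)CCN(c1ccccc1)[C@H]1c2cc(C#N)ccc2OC(C)(C)[C@@H]1O` gives 54000 nM. The three measured steps, a step that the limit leaves unreadable from compound 1 to compound 2, a step that the two limits leave unreadable from compound 1 to compound 3 and a step that the limit leaves unreadable from compound 2 to compound 3, are all unreadable in size, since the limit of > 30000 nM in this assay, at which 2 of the 3 values shown sit, covers two of the three values.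

Compound 4 `Cc1noc(CN(c2ccccc2)[C@H]2c3cc(C#N)ccc3OC(C)(C)[C@@H]2O)n1` differs from compound 3 by 3-methyl-1,2,4-oxadiazol-5-yl in place of acetamidomethyl on a saturated chain carbon bound to a nitrogen on an aromatic ring. Within the data shown here, no measured step resolves a change of this kind. Compound 4 is therefore expected to sit near the same limit, with an estimated step that the limit leaves unreadable from compound 3 to compound 4 from compound 3. The expected value for compound 4 is 35000 nM, ranging from 8000 nM to 150000 nM.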

Compound 4, half-maximal inhibitory concentration: > 30000 nM
Compound 4 gave a limit, no number; the forecaster's own chance of this, stated with the estimate: 60%; the middle value lies beyond the limit too.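

Compound 4 gives > 30000 nM as a limit, not a number. No step from compound 1, compound 2 or compound 3 to compound 4 can be read, because the values meet one limit: the limit of > 30000 nM in this assay, at which 3 of the 4 values shown sit.
The compounds shown leave open how far these side chains differ in this assay.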